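This account rests on a few compounds, and the source may have more. Where it says the series, first, only, none or still open, it means among the compounds named here.

Measured so far in a functional assay on HeLa cells (Homo sapiens) for inhibition, read by CCK-8 assay, with a stated time of 48 h; on this read-out higher numbers stand for weaker inhibition and lower numbers for stronger inhibition:

compound 1, `Cc1ccc(C2=NN(C3=NC(c4ccccc4)CS3)C(c3ccc4ccccc4c3)C2)cc1`, 2460 nM
compound 2, `Brc1ccc(C2=NN(C3=NC(c4ccccc4)CS3)C(c3ccc4ccccc4c3)C2)cc1`, 4960 nM
compound 3, `Cc1ccc(C2=NN(C3=NC(c4ccccc4)CS3)C(c3ccc4ccccc4c3)C2)cc1C`, 950 nM

Compound 3 gives the lowest number of the three in this assay, and its steps to both others lie beyond the scatter, so it is the strongest inhibitor of this small set. Compound 4, `Clc1ccc(C2=NN(C3=NC(c4ccccc4)CS3)C(c3ccc4ccccc4c3)C2)cc1`, carries the change (4-chlorophenyl in place of 3,4-dimethylphenyl on a carbon with a double bond to nitrogen). Two earlier steps speak to it. Adding the second methyl brought a 2.6-fold lower number from compound 1 to compound 3 (0.41 log units; beyond the scatter), so taking it away again should move the number back up by about that much. Swapping a methyl for a halogen brought a 2.0-fold higher number from compound 1 to compound 2 (0.30 log units; within the scatter), a change within the scatter, and chlorine here stands in for bromine. Taken together, the direct comparison a 5.2-fold lower number from compound 2 to compound 3 (0.72 log units; beyond the scatter) is the closest guide: compound 4 is expected to land near compound 2, with a step of a 4.2-fold higher number from compound 3 to compound 4 (0.62 log units; beyond the scatter) in this assay. The estimate for compound 4 in this assay is therefore 4000 nM, with a range from 1500 nM to 11000 nM.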

Compound 4, half-maximal inhibitory concentration: 7560 nM
Beside the measured number, compound 4's estimate is 1.9-fold (0.28 log units) below it, within the range that was stated.
By their numbers in this assay, from the lowest: compound 3; then compounds 1, 2 and 4 (each within the scatter of the next, the first and the last beyond it).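

In this assay, chloro in place of bromo on the aromatic carbon gives a 1.5-fold higher number from compound 2 to compound 4 (0.18 log units; within the scatter) and so the two halogens cannot be told apart at this spot. Chloro in place of methyl, however, gives a 3.1-fold higher number from compound 1 to compound 4 (0.49 log units; beyond the scatter) and so a halogen now stands clearly apart from the single methyl, which the bromo step, lying within the scatter, could not show. The full change, 4-chlorophenyl in place of 3,4-dimethylphenyl, gives an 8.0-fold higher number from compound 3 to compound 4 (0.90 log units; beyond the scatter) and is the largest step in this set, leaving the 3,4-dimethylphenyl group with the strongest inhibition of the four compounds.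

As far as these compounds go, whether an amine, a methoxy group or a carboxylic acid on this phenyl ring would side with the methyl groups or with the halogens stays open. Nothing at hand explains why these groups differ.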